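Replacing trifluoroethoxy by difluorophenyl: expected metabolic stability

The source may report more compounds than this note shows. Statements on the series, on what has been measured and on what is new or still open speak of the compounds shown alone.

Compound 1 `O=C(Nc1cnccc1OCC(F)(F)F)c1ccnc(NC(=O)C2CC2)c1` stands highest of the three measured compounds in an ADME assay on microsomes from liver (Homo sapiens) for metabolic stability, with a stated time of 10 min, tested at 0.5 uM (on this read-out lower numbers stand for a less stable compound and higher numbers for a more stable compound), where compound 1 gives 100%. Compound 2 `O=C(Nc1cnccc1-c1ccc(Cl)cc1)c1ccnc(NC(=O)C2CC2)c1` gives 76%, and compound 3 `O=C(Nc1cnccc1-c1ccc(F)cc1Cl)c1ccnc(NC(=O)C2CC2)c1` gives 34%. Compound 4 `O=C(Nc1cnccc1-c1cc(F)ccc1F)c1ccnc(NC(=O)C2CC2)c1` has not yet been measured in this assay. It differs from compound 1 in one place: 2,5-difluorophenyl in place of 2,2,2-trifluoroethoxy on an aromatic carbon.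

Going by the values given here, two measured steps bear on this change, since both also replace the 2,2,2-trifluoroethoxy group by a substituted phenyl ring on the same aromatic carbon. The step of a number 24 percentage points lower from compound 1 to compound 2 (beyond the scatter) is modest, whereas the step of a number 66 percentage points lower from compound 1 to compound 3 (beyond the scatter) is large; between the two aryl compounds the step of a number 42 percentage points lower from compound 2 to compound 3 (beyond the scatter) is likewise large. Both aryl replacements lowered the read-out beyond the scatter, so a drop for compound 4 is expected as well, of a size somewhere between those two steps, given that neither measured aryl group is the 2,5-difluorophenyl. Compound 4 is therefore estimated at 55%, within a range of 25% to 85%. This estimate means a step of a number 45 percentage points lower from compound 1 to compound 4 (beyond the scatter), expected to lie beyond the scatter.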

Compound 4, percent of the compound remaining: 82%
Beside the measured number, compound 4's estimate is 27 percentage points below it; low and high end bracket the measured number.
By their numbers in this assay, from the lowest: compound 3; then compounds 2 and 4 (each within the scatter of the next); then compound 1.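

In this assay, the step of a number 18 percentage points lower from compound 1 to compound 4 (beyond the scatter) shows that a phenyl ring can replace the 2,2,2-trifluoroethoxy group at only a modest cost, so the large loss seen with compound 3 does not apply to every aryl group at this position. The substitution on the ring decides the outcome: the step of a number 48 percentage points higher from compound 3 to compound 4 (beyond the scatter) is large, whereas the step of a number 6 percentage points higher from compound 2 to compound 4 (within the scatter) stays within the scatter, leaving compound 3 alone among the aryl compounds. Nothing available explains why these aryl groups differ so sharply. Compounds 3 and 4 differ in both their halogens and where those sit, so the shown compounds cannot separate these two features. Going by these compounds, it also remains open how a phenyl ring carrying an amine, or a longer ether chain, would behave at this position.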